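This account rests on a few compounds, and the source may have more. Where it says the series, first, only, none or still open, it means among the compounds named here.

Compound 2, `CCCCCOC(=O)N1CCN(C(=O)[C@H](CCC(=O)O)NC(=O)c2cc(N3CCC(COC)CC3)nc(-c3ccccc3)n2)CC1`, and compound 1, `CCCCCOC(=O)N1CCN(C(=O)[C@H](CCC(=O)O)NC(=O)c2cc(N3CCC(OCCO)CC3)nc(-c3ccccc3)n2)CC1`, share one core and differ only in the group on a saturated ring carbon. In an in vivo ADME assay on the whole organism (strain Sprague-Dawley) for pharmacokinetics, with Rattus norvegicus as the target (on this read-out lower numbers stand for slow clearance and higher numbers for fast clearance), compound 1 gives 18 mL/min/kg, and compound 2 gives 14 mL/min/kg. Among the measured compounds shown here, the single step measured so far is a 1.3-fold lower number from compound 1 to compound 2 (0.11 log units; within the scatter). Compound 2 therefore holds the lower of the two numbers shown, but the gap to compound 1 lies within the scatter, so the two cannot be told apart.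

Compound 3, `CCCCCOC(=O)N1CCN(C(=O)[C@H](CCC(=O)O)NC(=O)c2cc(N3CCC(C(N)=O)CC3)nc(-c3ccccc3)n2)CC1`, has not yet been measured. It differs from compound 2 in one place: carbamoyl in place of methoxymethyl on a saturated ring carbon.

For the measured compounds named here, the only measured step that bears on this change is the one from compound 1 to compound 2, at the same saturated ring carbon, and it stayed within the scatter. With one such step and no measured carbamoyl for comparison, the expected outcome in this assay is a step that stays within the scatter, with no clear direction, so the expected step is a 1.1-fold higher number from compound 2 to compound 3 (0.03 log units; within the scatter). Compound 3 is accordingly estimated at 15 mL/min/kg, with a range from 8 mL/min/kg to 28 mL/min/kg.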

Compound 3, clearance: 68 mL/min/kg
Compound 3: middle estimate off by 4.5-fold (0.66 log units), on the low side; the measured number lies above the stated range.
By their numbers in this assay, from the lowest: compounds 2 and 1 (each within the scatter of the next); then compound 3.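

The step between compound 1 and compound 2 stayed within the scatter and gave no sign that this saturated ring carbon matters, but carbamoyl changes that picture: in this assay the swap from methoxymethyl gives a 4.9-fold higher number from compound 2 to compound 3 (0.69 log units; beyond the scatter) and the swap from 2-hydroxyethoxy gives a 3.8-fold higher number from compound 1 to compound 3 (0.58 log units; beyond the scatter) on the same carbon. The group here can therefore move the clearance beyond the scatter, even though methoxymethyl and 2-hydroxyethoxy cannot be told apart. Methoxymethyl and carbamoyl have the same count of heavy atoms, and carbamoyl brings a hydrogen-bond donor and a double bond that methoxymethyl lacks, but no measurement here explains why the number rises with this change.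

The compounds shown leave open whether the rise belongs to carbamoyl alone or would also appear with a related group on the same ring carbon, such as a carboxylic acid, an amine or a nitrile. They also leave open whether the same swap would have a similar effect on a core other than the shared one.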